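A few compounds are considered here, and "the series" means these few. Any claim that something is new, unique, unknown or untested is made for them only; others in the source may bear on it.

Two compounds share one core and differ only in the group on a single aromatic carbon. Compound 1 `C#CCSc1nc(Nc2ccc(C)cc2)c2ccncc2n1` carries a methyl there, and in a functional assay on PC-3 cells (Homo sapiens) for inhibition, read by MTT assay, with a stated time of 72 h (a lower number here means a stronger inhibitor, a higher number a weaker inhibitor), compound 1 gives 15700 nM. Compound 2 `C#CCSc1nc(Nc2ccc(Br)cc2)c2ccncc2n1` carries a bromo at the same place, and in this assay compound 2 gives 26000 nM. The step of a 1.7-fold higher number from compound 1 to compound 2 (0.22 log units; within the scatter) shows how little that exchange changed the number. Among the compounds with values here, of the two values measured so far, compound 2 nominally has the highest, but compound 1 lies within the scatter of it, so neither can be called the weaker inhibitor.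

Compound 3 `C#CCSc1nc(Nc2ccc([N+](=O)[O-])cc2)c2ccncc2n1` alters the same position once more: nitro in place of bromo on an aromatic carbon, on an aromatic carbon of a six-membered aromatic ring of carbon only, para to a large group. Within the data shown here, only one measured step bears on this exchange, the methyl-to-bromo change from compound 1 to compound 2, and it stayed within the scatter. A further exchange at this position is therefore expected to give a step of a 1.0-fold lower number from compound 2 to compound 3 (0.02 log units; within the scatter) that does not go beyond the scatter in either direction. For compound 3 in this assay the estimate is 25000 nM, with a range from 8000 nM to 80000 nM.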

Compound 3, half-maximal inhibitory concentration: > 80000 nM
Compound 3: a limit, no number (the forecaster's own chance of this, stated with the estimate: 10%); middle value at least 3.2-fold (0.50 log units) from the limit.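

In this assay compound 3 gives no number, only a limit of the assay: the limit of > 80000 nM in this assay, at which 1 of the 3 values shown sits. Even so, nitro in place of bromo gives an at least 3.0-fold higher number from compound 2 to compound 3 (0.48 log units; beyond the scatter), and nitro in place of methyl gives an at least 5.0-fold higher number from compound 1 to compound 3 (0.70 log units; beyond the scatter), so this aromatic carbon, which seemed indifferent while only methyl and bromo could be compared, does respond to the group placed on it. Both steps are printed as beyond the scatter, which makes compound 3 the weakest inhibitor of the three, although the limit leaves the true size of each step unknown.

Nitro differs from bromo in more than one countable way, with more heavy atoms and two hydrogen-bond acceptors where bromo has none, and three compounds cannot show which of these differences, if any, goes with the weaker inhibition. Going by these compounds, it also remains open whether an amine, a carboxylic acid or a longer chain on this same carbon would stay close to the values of compound 1 and compound 2 or move beyond the scatter as nitro does.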